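A few compounds are considered here, and "the series" means these few. Any claim that something is new, unique, unknown or untested is made for them only; others in the source may bear on it.

Measured so far: compound 1 `CC1=C(C(=O)OCc2ccccc2)C(c2ccco2)NC(=S)N1` with 32%; compound 2 `CC1=C(C(=O)OCc2ccccc2)C(c2ccoc2)NC(=S)N1` with 25%; compound 3 `CC1=C(c2ncc(C)o2)C(c2ccco2)NC(=O)N1` with 27%.

All three were tested in an assay on membranes from CHO cells for displacement of a labelled ligand from adenosine receptor A1 (Homo sapiens), read by scintillation counting, with a stated time of 60 min, tested at 1 uM; on this read-out higher numbers stand for more inhibition at the one concentration tested (going by the name of the read-out) and lower numbers for less inhibition. Compound 1 and compound 2 share a core and differ in one place: furan-3-yl in place of furan-2-yl on a saturated ring carbon. This change gave a number 7 percentage points lower from compound 1 to compound 2 (within the scatter). The core of compound 3 differs from that of compound 1, but the difference between the two cores is not broken down here; in this assay compound 3 and compound 2 give numbers within the scatter of each other.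

Compound 4 `CC1=C(c2ncc(C)o2)C(c2ccoc2)NC(=O)N1` is not yet measured. It arises from compound 3 by the same kind of change: furan-3-yl in place of furan-2-yl on a saturated ring carbon. Around the place the surroundings differ, since in compound 4 the saturated ring carbon is next to the ring atom that bears a 5-methyl-1,3-oxazol-2-yl group, whereas in compound 2 that ring atom bears a large group. Because a number 7 percentage points lower from compound 1 to compound 2 (within the scatter) was within the scatter, the step is expected to be small as well, a number 5 percentage points lower from compound 3 to compound 4 (within the scatter). Compound 4 is therefore estimated at 22%, with a likely range from 8% to 38%.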

Compound 4, a percentage reported as inhibition, at one concentration (the size of the read-out at that concentration, not a potency): 21%
Beside the measured number, compound 4's estimate is 1 percentage points above it; the measured number falls inside the stated range.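

In this assay, furan-3-yl in place of furan-2-yl on the saturated ring carbon gave a number 6 percentage points lower from compound 3 to compound 4 (within the scatter). Set beside the earlier step, the change carries from one core to the other with no visible difference: the same change on two cores in this assay, a number 7 percentage points lower (within the scatter) from compound 1 to compound 2 and a number 6 percentage points lower (within the scatter) from compound 3 to compound 4, 1 percentage points apart, within the scatter of two such steps Both steps lie within the scatter, however, so the pair does not show that furan-3-yl and furan-2-yl truly differ on either core, and two cores do not establish how the change would behave on others.

The compounds shown leave open how a group other than a furan would read on that saturated ring carbon, for instance a phenyl ring, a thiophene or an amine. They also give no potency, only readings at one concentration.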